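Swapping the Aromatic Ring for Isopropyl on the Chain

The compounds below may be only part of what the source reports. "The series", "measured", "known", "first", "only" and "open" are said of these compounds alone.

Compound 2 `O=C1CC(c2ccccc2OCc2cccc(F)c2)Oc2ccccc21` gives the highest of the three numbers in a functional assay on RAW264.7 cells (Mus musculus) for inhibition, read by immunoassay, with a stated time of 12 h, tested at 30 uM (a higher number here means more inhibition at the concentration tested (going by the name of the read-out), a lower number less inhibition), with 93.3%; compound 3 `CC(C)c1ccc(COc2ccccc2C2CC(=O)c3ccccc3O2)cc1` gives 91.5%, a gap within the usual scatter, so the two cannot be ranked. Compound 1 `C=CCOc1ccccc1C1CC(=O)c2ccccc2O1`, which carries vinyl on the saturated chain carbon bound to an oxygen on an aromatic ring, gives 49.3%. Compound 4 `CC(C)COc1ccccc1C1CC(=O)c2ccccc2O1` is the unmeasured member, and it differs from compound 2 thus: isopropyl in place of 3-fluorophenyl on a saturated chain carbon bound to an oxygen on an aromatic ring. The measured steps that bear on this are a number 44 percentage points higher from compound 1 to compound 2 (beyond the scatter) and a number 42.2 percentage points higher from compound 1 to compound 3 (beyond the scatter), both large rises when an aromatic ring replaced a group without a ring, while a number 1.8 percentage points lower from compound 2 to compound 3 (within the scatter) shows the two rings gave the same outcome. Isopropyl, like vinyl, brings no ring, so a large fall is expected: a number 38.3 percentage points lower from compound 2 to compound 4 (beyond the scatter). Compound 4 is therefore estimated at 55%, within 35% to 78%.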

Compound 4, a percentage reported as inhibition, at one concentration (the size of the read-out at that concentration, not a potency): 30.4%
For compound 4 the middle estimate is 24.6 percentage points above the measured one; measured number below the stated range.
By their numbers in this assay, from the lowest: compound 4; then compound 1; then compounds 3 and 2 (each within the scatter of the next).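

Isopropyl in place of a ring costs about as much from either ring-bearing compound in this assay (a number 62.9 percentage points lower from compound 2 to compound 4 (beyond the scatter); a number 61.1 percentage points lower from compound 3 to compound 4 (beyond the scatter)). The new finding is that the two groups without a ring also separate (a number 18.9 percentage points lower from compound 1 to compound 4 (beyond the scatter)), so having no ring does not alone set the number, and isopropyl gives the lowest of the four. Nothing available explains this gap between vinyl and isopropyl. Still open, as far as these compounds go, is whether a saturated ring such as cyclohexyl would behave like the aromatic rings or like isopropyl, and where an amine at this place would fall.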